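The source may hold more compounds than are shown below. What is called first, only, known or untested is meant among the compounds shown, and "the series" means these compounds.

Working notes on the series. Going by the values given here, compound 1, `O=C1/C(=C\c2ccccc2Cl)c2ccccc2N1c1c(Cl)cccc1Cl`, is the only member with a number in a functional assay on MOLT-4 cells (Homo sapiens) for cytotoxicity, read by MTT assay, with a stated time of 72 h; on this read-out lower numbers stand for an effect already at smaller amounts and higher numbers for an effect only at larger amounts of compound: there compound 1 gives 7 ug/mL. Compound 2, `O=C1/C(=C\c2cc3ccccc3nc2Cl)c2ccccc2N1c1c(Cl)cccc1Cl`, belongs to the same set, but in this assay compound 2 carries "not determined" (no result reported), so compound 1 stands alone and no comparison between measured members can be drawn.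

The step now followed leads from compound 1 to compound 3, `O=C1/C(=C\c2cccc(Cl)c2)c2ccccc2N1c1c(Cl)cccc1Cl`. The change is 3-chlorophenyl in place of 2-chlorophenyl on a double-bonded chain carbon bound to a double-bonded ring carbon. The two compounds hold the same atoms and differ only in where the chlorine sits on the ring that hangs off the double-bonded chain carbon; the shared core and the dichlorophenyl on the ring nitrogen stay as they are.

Among the compounds with values here, with no pair of measured compounds to calibrate a step of this kind, the expectation rests on compound 1 alone. For compound 3 the step of no change at the digits printed from compound 1 to compound 3 (within the scatter) is expected to stay within the usual scatter of this assay, in no particular direction. Compound 3 is therefore estimated to give about 7 ug/mL in this assay, with a range from 3 ug/mL to 16 ug/mL.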

Compound 3, concentration for half-maximal effect: 6 ug/mL
For compound 3 the middle estimate is 1.2-fold (0.07 log units) above the measured one; the range from low to high includes it.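

In this assay, going by these compounds alone, 3-chlorophenyl in place of 2-chlorophenyl on a double-bonded chain carbon bound to a double-bonded ring carbon gives a 1.2-fold lower number from compound 1 to compound 3 (0.07 log units; within the scatter) and is the first step that can be read. At this position, the two chlorophenyl groups therefore cannot be told apart in this assay, so the chlorine's place on this ring, tested across these two compounds only, leaves the read-out within the scatter. No measurement shown offers an explanation for this result.

Compound 1 and compound 3 both carry a chlorophenyl group at this position, and compound 2 has no number to add, so they leave open whether the chlorine itself matters for the read-out. From the compounds shown here alone, it also remains open whether an unsubstituted phenyl, a 4-chlorophenyl or an aminophenyl at this position, or another group in place of the dichlorophenyl on the ring nitrogen, would stay in the same range.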